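Thiomorpholine Sulfonamide Weighed Against Its Pyrrolidine Parent

This account rests on a few compounds, and the source may have more. Where it says the series, first, only, none or still open, it means among the compounds named here.

Compound 1 `CC(O)(C(=O)Nc1ccc(S(=O)(=O)N2CCCC2)cc1)C(F)(F)F` is the reference of this set. In an assay on a protein complex (Cavia porcellus) with sulfonylurea receptors; K-ATP channels (Homo sapiens) as the target (on this read-out higher numbers stand for weaker inhibition and lower numbers for stronger inhibition), compound 1 gives 880 nM, the higher of the two numbers measured; compound 2 `CN(C)S(=O)(=O)c1ccc(NC(=O)C(C)(O)C(F)(F)F)cc1` gives 480 nM, and the change a 1.8-fold lower number from compound 1 to compound 2 (0.26 log units; within the scatter) stays within the scatter. Compound 3 `CC(O)(C(=O)Nc1ccc(/C(=N\O)c2ccccc2)cc1)C(F)(F)F` is reported only as a limit, > 30000 nM, (the limit of > 30000 nM in this assay, at which 1 of the 3 values shown sits). Compound 4 `CC(O)(C(=O)Nc1ccc(S(=O)(=O)N2CCSCC2)cc1)C(F)(F)F` differs from compound 1 by thiomorpholin-4-yl in place of pyrrolidin-1-yl on a sulfonyl sulfur. Among the measured compounds shown here, the only measured step at the same place, the swap of amines on the sulfonyl sulfur between compound 1 and compound 2, stayed within the scatter, so no step beyond the scatter is expected here either. Compound 4 is therefore estimated at 900 nM, with a range from 300 nM to 2700 nM. This estimate amounts to an expected step of a 1.0-fold higher number from compound 1 to compound 4 (0.01 log units; within the scatter).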

Compound 4, half-maximal inhibitory concentration: 4580 nM
Compound 4: the middle estimate sits 5.1-fold (0.71 log units) below what was measured, and the stated range ends below it.
By their numbers in this assay, from the lowest: compounds 2 and 1 (each within the scatter of the next); then compound 4. At a limit, above all of these: compound 3.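

In this assay the group on the sulfonyl sulfur now proves to matter: thiomorpholin-4-yl in place of pyrrolidin-1-yl gives a 5.2-fold higher number from compound 1 to compound 4 (0.72 log units; beyond the scatter) and, in place of dimethylamino, gives a 9.5-fold higher number from compound 2 to compound 4 (0.98 log units; beyond the scatter) on the same position. The earlier swap between compound 1 and compound 2 stayed within the scatter, so this position tolerates some amines but not every one. Going by these compounds, whether piperidin-1-yl or morpholin-4-yl on this sulfonyl sulfur would stay with compound 1 or fall with compound 4 remains open. Nothing measured here bears on what lies behind this step.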